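This account rests on a few compounds, and the source may have more. Where it says the series, first, only, none or still open, it means among the compounds named here.

Measured in a functional assay on HeLa cells (Homo sapiens) for cytotoxicity, with a stated time of 72 h; a lower number here means a stronger inhibitor, a higher number a weaker inhibitor:
Compound 1 `Cc1ccc(-c2cn3nc(Cc4ccc(Cl)cc4)sc3n2)cc1` gives > 250000 nM, a limit of the assay.
Compound 2 `Fc1ccc(-c2nc3sc(Cc4ccc(Cl)cc4)nn3c2Br)cc1` gives > 250000 nM, also a limit.
Compound 3 `Clc1ccc(Cc2nn3c(Br)c(-c4ccc(Br)cc4)nc3s2)cc1` gives 188000 nM.

Going by the values given here, compound 3 thus holds the only actual number among the three, the other two values being limits (the limit of > 250000 nM in this assay, at which 2 of the 3 values shown sit). Among the compounds with values here, the single measured one-place change, an at least 1.3-fold lower number from compound 2 to compound 3 (0.12 log units; that floor lies within the scatter), lies within the scatter. Compound 4 `Cc1ccc(-c2nc3sc(Cc4ccc(Cl)cc4)nn3c2Br)cc1` differs from compound 3 by methyl in place of bromo on an aromatic carbon. Within the data shown here, no measured step tests exactly this change; the only comparable step, the bromo-for-fluoro exchange, did not move the number beyond the scatter. Compound 4 is therefore expected to show a 1.3-fold higher number from compound 3 to compound 4 (0.12 log units; within the scatter), and its estimated value in this assay is 250000 nM, within 120000 nM to 600000 nM, with a real chance that only a limit is reported.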

Compound 4, half-maximal inhibitory concentration: > 250000 nM
Compound 4 was reported as a limit; the forecaster's own chance of this, stated with the estimate: 65%; the middle value lies on the limit itself.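

In this assay, the change from 4-bromophenyl to 4-methylphenyl gives an at least 1.3-fold higher number from compound 3 to compound 4 (0.12 log units; that floor lies within the scatter), so at this place neither methyl nor fluoro, each set against bromo, shows a floor beyond the scatter. The steps to compound 4 from compound 1 and from compound 2 cannot be read, as both ends of each are limits. Compound 3 remains the only one of the four with an actual number, the others being limits: the limit of > 250000 nM in this assay, at which 3 of the 4 values shown sit.

As far as these compounds go, the true size of the step from bromo to methyl stays open. So does whether an amine or a carboxylic acid at this place would give a clearly lower number.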